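Replacing Fluoro with Methoxy on a Compound 3 Scaffold

The source may hold more compounds than are shown below. What is called first, only, known or untested is meant among the compounds shown, and "the series" means these compounds.

Compound 1 `Fc1ccc2[nH]c(-c3cn(-c4ccccc4)nc3-c3ccccc3)nc2c1`: 3610 nM
Compound 2 `Fc1ccc(-c2nn(-c3ccccc3)cc2-c2nc3ccccc3[nH]2)cc1`: 2330 nM
Compound 3 `Fc1ccc(-c2nn(-c3ccccc3)cc2-c2nc3cc(F)ccc3[nH]2)cc1`: 1570 nM

These values come from a functional assay on HeLa cells (Homo sapiens) for antiproliferative activity, read by MTT assay, with a stated time of 48 h; a lower number here means a stronger inhibitor, a higher number a weaker inhibitor. Compound 3 lies within the scatter of compound 2 and clearly lower than compound 1. Compound 4 `COc1ccc2[nH]c(-c3cn(-c4ccccc4)nc3-c3ccc(F)cc3)nc2c1` carries methoxy in place of fluoro on an aromatic carbon.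

Among the compounds with values here, two measured steps bear on this change, and both introduce fluoro in place of hydrogen. Compound 2 carries hydrogen where compound 3 carries fluoro, which makes a 1.5-fold lower number from compound 2 to compound 3 (0.17 log units; within the scatter) the closer guide. The other, a 2.3-fold lower number from compound 1 to compound 3 (0.36 log units; beyond the scatter), concerns a different aromatic carbon and is modest. Within the data shown here, no measured compound carries methoxy, so the data give only indirect guidance. Since replacing hydrogen at this place with fluoro in compound 3 gave only a 1.5-fold lower number from compound 2 to compound 3 (0.17 log units; within the scatter), no shift beyond the scatter is expected in this assay, and no direction is favoured. The expected change is a 1.1-fold higher number from compound 3 to compound 4 (0.03 log units; within the scatter). Compound 4 is estimated at 1700 nM, with an expected range of 650 nM to 4400 nM.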

Compound 4, half-maximal inhibitory concentration: 7510 nM
Compound 4: middle estimate off by 4.4-fold (0.65 log units), on the low side; measured number above the stated range.
By their numbers in this assay, from the lowest: compounds 3, 2 and 1 (each within the scatter of the next, the first and the last beyond it); then compound 4.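

In this assay, this aromatic carbon proved not to be indifferent to what it carries: hydrogen and fluoro had stood within the scatter of each other here, whereas methoxy gives a 4.8-fold higher number from compound 3 to compound 4 (0.68 log units; beyond the scatter) and, against hydrogen, a 3.2-fold higher number from compound 2 to compound 4 (0.51 log units; beyond the scatter) with the rest of the molecule unchanged. Both steps lie beyond the scatter and point the same way, so methoxy at this place weakens the antiproliferative effect relative to either smaller group. Nothing measured here gives a reason for this shift.

The compounds shown leave open whether the same weakening would follow with hydroxy, ethoxy or an amine on this aromatic carbon. They also leave open how methoxy would behave on the different aromatic carbon that carries fluoro in compound 3 and hydrogen in compound 1.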